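A few compounds are considered here, and "the series" means these few. Any claim that something is new, unique, unknown or untested is made for them only; others in the source may bear on it.

Working notes on the series. The shared core is carried by compound 1 `C=Cc1cccc(-c2[nH]c3cc(OC)ccc3c(=O)c2C(=O)OCC)c1`, compound 2 `CCOC(=O)c1c(-c2cccc(OC)c2)[nH]c2cc(OC)ccc2c1=O` and compound 3 `CCOC(=O)c1c(-c2cccc(OCc3ccccc3)c2)[nH]c2cc(OC)ccc2c1=O`; the three differ only in one group on an aromatic carbon. In an ADME assay on Raji cells (Homo sapiens) for cytotoxicity, read by luminescence, with a stated time of 72 h (on this read-out lower numbers stand for an effect already at smaller amounts and higher numbers for an effect only at larger amounts of compound), compound 1 gives > 21500 nM, which is a limit of the assay and not a number. In the same assay compound 2 gives > 21500 nM, again a limit. Compound 3 gives > 21500 nM in this assay, also a limit. Compound 2 thus stands at the limit, together with every other value shown (the limit of > 21500 nM in this assay, at which 3 of the 3 values shown sit). The steps a step that the two limits leave unreadable from compound 1 to compound 2, a step that the two limits leave unreadable from compound 1 to compound 3 and a step that the two limits leave unreadable from compound 2 to compound 3 remain unreadable in both size and direction.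

The change now followed leads to compound 4 `CCOC(=O)c1c(-c2cccc(C(F)(F)F)c2)[nH]c2cc(OC)ccc2c1=O`: trifluoromethyl in place of methoxy on an aromatic carbon. For the measured compounds named here, none of the measured steps reads on this exchange; the only guidance is the limit of > 21500 nM in this assay, at which 3 of the 3 values shown sit, where all three values sit at the limit. For compound 4 the step that the limit leaves unreadable from compound 2 to compound 4 is expected to lie within the scatter, with no direction to be read. Compound 4 is expected at 30000 nM in this assay, within 15000 nM to 100000 nM, and most probably reported once more as a limit.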

Compound 4, half-maximal effective concentration: > 21500 nM
Compound 4 was reported as a limit (the forecaster's own chance of this, stated with the estimate: 85%); the middle value does not contradict the limit.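

In this assay compound 4 gives > 21500 nM, again a limit of the assay and not a number. The steps to compound 4 from compound 1, compound 2 and compound 3 cannot be read in size or direction. The compounds shown leave open whether any exchange of this group gives a readable value: the limit of > 21500 nM in this assay, at which 4 of the 4 values shown sit.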